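The source may hold more compounds than are shown below. What is called first, only, known or untested is meant among the compounds shown, and "the series" means these compounds.

Compound 1 `CCN(CC)C(=O)C1=C(C)NC(=O)NC1c1ccco1` gives 19% in an assay on membranes from HeLa cells for displacement of a labelled ligand from adenosine receptor A3 (Homo sapiens), read by scintillation counting, with a stated time of 180 min, tested at 1 uM (on this read-out lower numbers stand for less inhibition and higher numbers for more inhibition at the one concentration tested (going by the name of the read-out)), the lower of the two measured numbers. Compound 2 `CCN(CC)C(=O)C1=C(C)NC(=O)NC1c1ccoc1` gives 37% in this assay, and a number 18 percentage points higher from compound 1 to compound 2 (beyond the scatter). Compound 3 `CC1=C(C(=O)OC2CCCCC2)C(c2ccco2)NC(=O)N1` differs from compound 1 by cyclohexyloxy in place of diethylamino on a carbonyl carbon. Among the measured compounds shown here, the only measured step concerns a group on a saturated ring carbon, not the carbonyl carbon, so no measured step bears directly on this change and nothing in the data points a direction for it. Compound 3 is therefore expected to give about 20% in this assay, with a range from 0% to 45%. That estimate means a number 1 percentage points higher from compound 1 to compound 3 (within the scatter), a step expected to stay within the scatter.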

Compound 3, a percentage reported as inhibition, at one concentration (the size of the read-out at that concentration, not a potency): 4%
Estimate against measurement, compound 3: 16 percentage points above; low and high end bracket the measured number.
By their numbers in this assay, from the lowest: compound 3; then compound 1; then compound 2.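

Among the compounds shown here, this is the first measured change on the carbonyl carbon, and it shows that the group there also moves the number in this assay: cyclohexyloxy in place of diethylamino gives a number 15 percentage points lower from compound 1 to compound 3 (beyond the scatter). The data offer no explanation for this fall.

The compounds shown leave open whether the fall follows the oxygen or the cyclohexyl ring, as neither ethoxy nor cyclohexylamino on this carbonyl carbon stands among them. Also open, going by these compounds, is how cyclohexyloxy behaves alongside furan-3-yl in place of furan-2-yl.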